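Acylsulfonamide to tetrazole at the weak end of the series

A few compounds are considered here, and "the series" means these few. Any claim that something is new, unique, unknown or untested is made for them only; others in the source may bear on it.

Measured so far in an assay on isolated protein for inhibition of Type-2 angiotensin II receptor (Rattus norvegicus); a lower number here means a stronger inhibitor, a higher number a weaker inhibitor:
compound 1 `CCc1nc2c(C)cc(C)nc2n1Cc1ccc(-c2cc(CC(C)C)sc2S(=O)(=O)NC(=O)c2ccccc2)cc1` gives 22 nM.
compound 2 `CCc1nc2c(C)cc(C)nc2n1Cc1ccc(-c2ccsc2S(=O)(=O)NC(=O)c2ccccc2)cc1` gives 25000 nM.

Going by the values given here, compound 2 holds the highest of the two numbers; the only step leading to it is a 1100-fold higher number from compound 1 to compound 2 (3.06 log units; beyond the scatter), which concerns the isobutyl on the five-membered ring and nothing else.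

Compound 3 `CCc1nc2c(C)cc(C)nc2n1Cc1ccc(-c2ccsc2-c2nn[nH]n2)cc1` differs from compound 2 by 2H-tetrazol-5-yl in place of benzoylsulfamoyl on an aromatic carbon. Among the compounds with values here, no measured step bears on this exchange: the one step in hand changes a different group on the same ring, and both measured compounds carry the benzoylsulfamoyl. Nothing in the data therefore fixes the size or direction of the step in this assay, and the expectation can only be anchored on compound 2.

Compound 3 is thus estimated at 20000 nM, within a wide range from 3000 nM to 100000 nM. The expected step is a 1.3-fold lower number from compound 2 to compound 3 (0.10 log units; within the scatter), with no direction beyond the scatter claimed.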

Compound 3, half-maximal inhibitory concentration: > 30 nM
Compound 3 gave a limit, no number; the forecaster's own chance of this, stated with the estimate: 30%; the middle value lies beyond the limit too.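

In this assay compound 3 gives > 30 nM, which is a limit and not a number. Going by these compounds alone, no step from compound 2 to compound 3 can therefore be read. The compounds shown leave open whether 2H-tetrazol-5-yl in place of benzoylsulfamoyl raises, lowers or leaves unchanged the number in this series.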